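A Rearranged Five-Carbon Chain and Expected Solubility

The source may hold more compounds than are shown below. What is called first, only, known or untested is meant among the compounds shown, and "the series" means these compounds.

Of the compounds shown here, three built on a shared core have been tested in a physicochemical assay for solubility, with a stated time of 18 h, at pH 7.4; a lower number here means a less soluble compound, a higher number a more soluble compound. Compound 1 `CC(C)CCc1ccc2c(NCCCNCc3ccco3)ccnc2c1` gives 4200 nM. Compound 2 `COc1cccc(CNCCCNc2ccnc3cc(CCC(C)C)ccc23)c1O` gives 4200 nM, and compound 3 `COc1ccc(F)cc1CNCCCNc1ccnc2cc(CCC(C)C)ccc12` gives 4200 nM. The three values are level with one another, so compound 2 stands neither apart from compound 1 nor from compound 3: the step of no change at the digits printed from compound 1 to compound 2 (within the scatter), the step of no change at the digits printed from compound 1 to compound 3 (within the scatter) and the step of no change at the digits printed from compound 2 to compound 3 (within the scatter) all stay within the scatter of the method, even though each exchanges the ring carried on the saturated chain carbon bound to the amine nitrogen.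

Compound 4 `CCC(CC)c1ccc2c(NCCCNCc3cccc(OC)c3O)ccnc2c1` has not yet been measured. It differs from compound 2 at a different place: pentan-3-yl in place of isopentyl on an aromatic carbon. Going by the values given here, none of the measured steps touches this aromatic carbon, so they give no direct guide to a change here; they show only that rearranging groups on the far end of the molecule left this assay unchanged. With the same atoms joined differently and no shift in donors, acceptors or charge, no step beyond the scatter is expected.

Compound 4 is therefore estimated at 4200 nM, within 2000 nM to 8500 nM, an expected step of no change at the digits printed from compound 2 to compound 4 (within the scatter).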

Compound 4, solubility: 4200 nM
Beside the measured number, compound 4's estimate shows no gap at the digits printed; low and high end bracket the measured number.
By their numbers in this assay, from the lowest: compounds 1, 2, 3 and 4 (each within the scatter of the next).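

Compounds 1, 2 and 3 differ only in the ring on the saturated chain carbon bound to the amine nitrogen, whereas compound 4 brings a change at an aromatic carbon of the shared core. In this assay, this change of chain gives no change at the digits printed from compound 2 to compound 4 (within the scatter) and so extends the level picture to a second place in the molecule. This rests on one pair, with the 2-hydroxy-3-methoxyphenyl ring in place, and nothing available here accounts for the result.

Both chains have five carbons, no ring, no hydrogen-bond donors or acceptors and no net charge, so this pair says nothing about a group at this aromatic carbon that differs in any of these counts. Still open, going by these compounds, is whether a shorter ethyl chain, a cyclohexyl ring, or a chain ending in an amine or a carboxylic acid would leave the read-out just as level.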